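Aryl sulfonamide variation on a spiro-amine series

The source may hold more compounds than are shown below. What is called first, only, known or untested is meant among the compounds shown, and "the series" means these compounds.

Working notes on the series. Compound 1 `CCOCCN(C[C@@H](O)CN1CCC2(CCN(c3ncnc4[nH]nc(C)c34)C2)C1)S(=O)(=O)c1c(C)cccc1C` gives 3100 nM in an assay on LNCaP cells for inhibition of RAC-alpha serine/threonine-protein kinase (Homo sapiens); on this read-out lower numbers stand for stronger inhibition and higher numbers for weaker inhibition. Compound 2 `Cc1cccc(C)c1S(=O)(=O)N1CCC[C@H]1[C@H](O)CN1CCC[C@@]2(CCN(c3ncnc(N)c3C3CC3)C2)C1` gives 13000 nM in this assay, and compound 3 `Cc1cccc(C)c1S(=O)(=O)NC[C@@H](O)CN1CCC[C@@]2(CCN(c3ncnc(N)c3C3CC3)C2)C1` gives 900 nM. Compound 3 thus stands lowest of the three numbers, beyond the scatter from compound 1 and further still from compound 2. Compound 4 `Cc1cc(F)ccc1S(=O)(=O)NC[C@@H](O)CN1CCC[C@@]2(CCN(c3ncnc(N)c3C3CC3)C2)C1` is not yet measured; it differs from compound 3 by 4-fluoro-2-methylphenyl in place of 2,6-dimethylphenyl on a sulfonyl sulfur. Among the compounds with values here, no measured pair shows this change, so no step for it can be read from the data. For compound 4 a small shift is expected, a 1.3-fold higher number from compound 3 to compound 4 (0.12 log units; within the scatter), probably not beyond the scatter, with a slight lean toward a higher number. Compound 4 is therefore estimated at 1200 nM, within a range of 400 nM to 3500 nM.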

Compound 4, half-maximal inhibitory concentration: 2200 nM
Compound 4: the middle estimate sits 1.8-fold (0.26 log units) below what was measured; measured number inside the range.
By their numbers in this assay, from the lowest: compound 3; then compounds 4 and 1 (each within the scatter of the next); then compound 2.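

Within the data shown here, on the sulfonyl sulfur, the aryl group is not a silent exchange in this assay: 4-fluoro-2-methylphenyl in place of 2,6-dimethylphenyl gives a 2.4-fold higher number from compound 3 to compound 4 (0.39 log units; beyond the scatter) and this is the first step that can be read at a single place. Of these two groups, 2,6-dimethylphenyl gives the lower number. No measurement at hand accounts for this step.

Going by these compounds, the fluorine and the moved methyl change together, so their separate shares stay open. Also open, on these data alone, is how 2-methylphenyl or a pyridyl ring would read on this sulfur.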